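The source may report more compounds than this note shows. Statements on the series, on what has been measured and on what is new or still open speak of the compounds shown alone.

Compound 3 `N/C(=N\NC(=S)N1CCCCC1)c1ccccn1` gives 88.5% in a functional assay on A-375 cells (Homo sapiens) for cytotoxicity, read by MTT assay, with a stated time of 72 h, tested at 100 uM (a lower number here means less inhibition of growth, a higher number more inhibition of growth at the concentration tested), the highest of the three measured numbers. Compound 1 `N/C(=N\NC(=S)N1CCOCC1)c1ccccn1` gives 14%, and compound 2 `Cc1cccc(/C(N)=N/NC(=S)N2CCSCC2)n1` gives 77.4%. Within the data shown here, the only measured step, a number 74.5 percentage points higher from compound 1 to compound 3 (beyond the scatter), concerns the ring on the thiocarbonyl carbon and does not touch the change at hand. Compound 4 `Cc1cccc(/C(N)=N/NC(=S)N2CCCCC2)n1` differs from compound 3 by methyl in place of hydrogen on an aromatic carbon. Among the measured compounds shown here, no measured pair isolates this change. Compound 2 carries the same methyl on a different ring and lies below compound 3 by a margin beyond the scatter, but the ring also differs, so this gives only a weak hint. Compound 4 is therefore estimated at 84%, within 62% to 97%, an expected step of a number 4.5 percentage points lower from compound 3 to compound 4 (within the scatter) that need not exceed the scatter.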

Compound 4, percent growth inhibition at one concentration: 85.7%
Compound 4: middle estimate off by 1.7 percentage points, on the low side; low and high end bracket the measured number.
By their numbers in this assay, from the lowest: compound 1; then compounds 2, 4 and 3 (each within the scatter of the next, the first and the last beyond it).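

In this assay, the step of a number 2.8 percentage points lower from compound 3 to compound 4 (within the scatter) comes from methyl in place of hydrogen next to the ring nitrogen, so with the piperidin-1-yl ring this change cannot be told from the scatter. With the methyl present, the ring swap gives a number 8.3 percentage points higher from compound 2 to compound 4 (within the scatter) and also stays within the scatter. Nothing here explains either result.

On these data alone, whether an amine, a methoxy group or a longer chain at this position would fit as well remains open. So does whether the methyl would matter alongside the morpholin-4-yl ring of compound 1.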